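Ethoxy substitution on the aryl ester of the thiazolidinedione series

This account rests on a few compounds, and the source may have more. Where it says the series, first, only, none or still open, it means among the compounds named here.

Measured compounds:
compound 1, `O=C(CC1SC(=O)NC1=O)Oc1ccc(/C=N/NC(=O)c2ccncc2)cc1Cl`, 31.9 ug/mL
compound 2, `O=C(CC1SC(=O)NC1=O)Oc1ccc(/C=N/NC(=O)c2ccncc2)cc1`, 91.7 ug/mL

In an ADME assay on Vero cells (Chlorocebus sabaeus) for cytotoxicity, read by MTT assay, with a stated time of 24 h (on this read-out lower numbers stand for stronger inhibition and higher numbers for weaker inhibition), compound 2 gives the highest of the two numbers shown, with compound 1 the nearer at a lower value. Among the measured compounds shown here, the one step with numbers, a 2.9-fold higher number from compound 1 to compound 2 (0.46 log units; beyond the scatter), shows that hydrogen in place of chloro on an aromatic carbon raised the number modestly. Compound 3, `CCOc1cc(/C=N/NC(=O)c2ccncc2)ccc1OC(=O)CC1SC(=O)NC1=O`, carries ethoxy in place of hydrogen on an aromatic carbon. For the measured compounds named here, no measured step concerns an ethoxy group, so only the chloro step offers a guide: placing a substituent on this ring lowered the number by a modest margin once. By that analogy compound 3 is expected to show a modest decrease, a 1.5-fold lower number from compound 2 to compound 3 (0.18 log units; within the scatter), though with wide uncertainty since the group differs. The estimate for compound 3 in this assay is 60 ug/mL, within a range of 30 ug/mL to 130 ug/mL.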

Compound 3, half-maximal inhibitory concentration: 50.9 ug/mL
Compound 3: middle estimate off by 1.2-fold (0.07 log units), on the high side, within the range that was stated.
By their numbers in this assay, from the lowest: compounds 1, 3 and 2 (each within the scatter of the next, the first and the last beyond it).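

In this assay, ethoxy in place of hydrogen on this aromatic carbon, ortho to a large group and meta to a large group, gives a 1.8-fold lower number from compound 2 to compound 3 (0.26 log units; within the scatter) and so, unlike the chloro step, stays inside the scatter of the unsubstituted compound. Ethoxy in place of chloro at the same carbon gives a 1.6-fold higher number from compound 1 to compound 3 (0.20 log units; within the scatter) and is likewise not separated from the chloro compound, so compound 3 cannot be told apart from either neighbour, even though those two neighbours differ beyond the scatter. Nothing available bears on the reason for these numbers.

From the compounds shown here alone, whether any group at this carbon takes the number clearly away from both compound 1 and compound 2 stays open. An amine, a carboxylic acid or a longer chain such as butoxy could answer that.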